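Working notes: compound 3 to compound 4

The compounds below may be only part of what the source reports. "The series", "measured", "known", "first", "only" and "open" are said of these compounds alone.

In a functional assay on Raji cells (Homo sapiens) for cytotoxicity, with a stated time of 72 h (a lower number here means a stronger inhibitor, a higher number a weaker inhibitor), compound 1 `CCOC(=O)/C=C/C=C/C=C/C=C/c1cccn1C` gives > 10000 nM, which is a limit and not a number. Compound 2 `CCOC(=O)/C=C/C=C/C=C/C=C/c1nccs1` gives > 10000 nM, also a limit. Compound 3 `CCOC(=O)/C=C/C=C/C=C/C=C/c1ccco1` gives > 10000 nM, again a limit. Compound 3 therefore stands at the limit of > 10000 nM in this assay, at which 3 of the 3 values shown sit.

The change to compound 4 `CCOC(=O)/C=C/C=C/C=C/C=C/c1[nH]ccc1Cl` is a group of 6 heavy atoms (4 carbon, 1 nitrogen, 1 chlorine; one five-membered aromatic ring with 1 hetero atom) in place of a group of 5 heavy atoms (4 carbon, 1 oxygen; one five-membered aromatic ring with 1 hetero atom), on a double-bonded chain carbon bound to a double-bonded chain carbon. The group that leaves is furan-2-yl, and the group that enters carries chlorine and a hydrogen-bond donor.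

The measured steps that bear on this change are a step that the two limits leave unreadable from compound 1 to compound 3 and a step that the two limits leave unreadable from compound 2 to compound 3. Neither gives a size that can carry over, and the same holds for a step that the two limits leave unreadable from compound 1 to compound 2. Within the data shown here, no step beyond the scatter is therefore expected in this assay, and no direction can be drawn from the series so far. The expected step is a number no higher from compound 3 to compound 4 (the limit leaves the size open). Another report as a limit would be in keeping with compounds 1, 2 and 3.

Compound 4 is estimated at 10000 nM, with an expected range of 2000 nM to 30000 nM.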

Compound 4, half-maximal inhibitory concentration: > 10000 nM
Compound 4: no number, only a limit; the forecaster's own chance of this, stated with the estimate: 65%; the middle value lies on the limit itself.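

In this assay compound 4 gives > 10000 nM, a limit and not a number, so its steps from compound 1, compound 2 and compound 3 cannot be read. The compounds shown leave open how these groups rank against one another, since all share one limit: the limit of > 10000 nM in this assay, at which 4 of the 4 values shown sit.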